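Swapping the Ring on the Thiocarbonyl Carbon

A few compounds are considered here, and "the series" means these few. Any claim that something is new, unique, unknown or untested is made for them only; others in the source may bear on it.

Three compounds have been measured in a functional assay on A-431 cells (Homo sapiens) for cytotoxicity, read by MTT assay, with a stated time of 72 h, tested at 1 uM; on this read-out lower numbers stand for less inhibition of growth and higher numbers for more inhibition of growth at the one concentration tested:
compound 1 `N/C(=N\NC(=S)N1CCCCCC1)c1ccccn1` gives 18.8%
compound 2 `N/C(=N\NC(=S)N1CCOCC1)c1ccccn1` gives 29.2%
compound 3 `Cc1ccnc(/C(N)=N/NC(=S)N2CCOCC2)c1` gives 33.6%

Compound 2 stands second highest of the three. Compound 3 sits closest to it, and a number 4.4 percentage points higher from compound 2 to compound 3 (within the scatter) is within the scatter. Compound 1 is furthest away, its value lying beyond the scatter below compound 2.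

Compound 4 `N/C(=N\NC(=S)N1CCCCC1)c1ccccn1` arises from compound 2 by piperidin-1-yl in place of morpholin-4-yl on a thiocarbonyl carbon. Among the measured compounds shown here, the only measured step, the methyl on the aromatic carbon, touches a different place and says nothing about this ring swap. For the measured compounds named here, no step is known between compound 1 and compound 2; their two values alone show that the all-carbon seven-membered ring of compound 1 goes with less growth inhibition than the morpholine of compound 2. On that slender basis, compound 4 is expected to give 22%, within 12% to 32%, meaning an estimated step of a number 7.2 percentage points lower from compound 2 to compound 4 (within the scatter) that may not clear the scatter.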

Compound 4, percent growth inhibition at one concentration: 24.4%
Beside the measured number, compound 4's estimate is 2.4 percentage points below it, within the range that was stated.
By their numbers in this assay, from the lowest: compounds 1, 4, 2 and 3 (each within the scatter of the next, the first and the last beyond it).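

In this assay the first single-place change measured on the thiocarbonyl carbon, piperidin-1-yl in place of morpholin-4-yl, reads a number 4.8 percentage points lower from compound 2 to compound 4 (within the scatter) and so does not clear the usual variation between repeats. At this position, giving up the ring oxygen and the one hydrogen-bond acceptor counted for morpholin-4-yl therefore leaves the growth inhibition indistinguishable at the one concentration tested. No available measurement bears on why this is so.

Still open, going by these compounds, is how this position responds to a ring carrying a second nitrogen, such as piperazin-1-yl, or to an open-chain group such as dimethylamino.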